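The source may hold more compounds than are shown below. What is called first, only, known or untested is meant among the compounds shown, and "the series" means these compounds.

Working notes on the series. For the measured compounds named here, compound 3 `CC(C)CC(=O)Nc1nc2ccc(NC(=O)c3c(Cl)cccc3Cl)cc2s1` holds the lowest of the three numbers so far in a functional assay on WI-38 VA13 cells (Homo sapiens) for cytotoxicity (a lower number here means that less compound is needed, a higher number that more compound is needed for the effect), giving 0.012 ug/mL. Going by the values given here, compound 1 `O=C(Nc1ccc2nc(NC(=O)C3CCCCC3)sc2c1)c1ccccc1C(F)(F)F` gives 0.024 ug/mL in this assay, a value that sits within the scatter of compound 3, so the two cannot be ranked against each other; they differ at both amide groups and no single step between them is recorded. Among the compounds with values here, compound 2 `Cc1coc(C)c1C(=O)Nc1ccc2nc(NC(=O)C3CCCCC3)sc2c1` gives 2.7 ug/mL in this assay, and the one recorded step, a 110-fold higher number from compound 1 to compound 2 (2.05 log units; beyond the scatter), shows that swapping the group on the aryl-side carbonyl can move the number a long way.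

The next compound, compound 4 `CCCCCCNC(=O)Nc1nc2ccc(NC(=O)c3c(Cl)cccc3Cl)cc2s1`, changes the other side of the core: hexylamino in place of isobutyl on a carbonyl carbon. Within the data shown here, no measured step touches this position, so the recorded step from compound 1 to compound 2 bears on it only as a warning that changes at an amide carbonyl in this core can be large; it gives no direction for the present change. With nothing closer to lean on, the working expectation for compound 4 is a step of a 2.1-fold higher number from compound 3 to compound 4 (0.32 log units; beyond the scatter), in either direction and probably within or near the scatter. Compound 4 is therefore estimated at 0.025 ug/mL in this assay, in a range from 0.006 ug/mL to 0.12 ug/mL.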

Compound 4, half-maximal effective concentration: 0.29 ug/mL
Compound 4: middle estimate off by 12-fold (1.06 log units), on the low side, and the stated range ends below it.
By their numbers in this assay, from the lowest: compounds 3 and 1 (each within the scatter of the next); then compound 4; then compound 2.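

For the compounds shown here, at this position, with the other amide group held constant, the only measured step, a 24-fold higher number from compound 3 to compound 4 (1.38 log units; beyond the scatter) in this assay, shows that the number responds strongly to the change from isobutylcarbonyl to hexylcarbamoyl, and here it rises. The earlier step, a 110-fold higher number from compound 1 to compound 2 (2.05 log units; beyond the scatter), came from a change on the other carbonyl, so large steps are now recorded at both amide groups of the shared core, though each rests on a single pair and on different remaining structure. Hexylamino differs from isobutyl in both chain and the added nitrogen with its hydrogen-bond donor, and no information at hand separates these differences or accounts for the step.

The compounds shown leave open whether the step follows the longer chain or the added nitrogen, a question that a hexyl group on the same carbonyl carbon and an isobutylamino group would help to separate. They also leave open whether the same change would give a comparable step with cyclohexyl on the other side of the core's amide arrangement, or with the 2-(trifluoromethyl)phenyl group in place of the present aryl group.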